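A few compounds are considered here, and "the series" means these few. Any claim that something is new, unique, unknown or untested is made for them only; others in the source may bear on it.

Compounds 1 and 2 share one core and differ only at a saturated chain carbon bound to an aromatic carbon. Compound 1 `C=CC(C)(C)c1[nH]c2ccc(C[C@H]3OC(C)(C)OC3(C)C)cc2c1/C=C1\NC(=O)[C@H](C)NC1=O` gives 88000 nM in a functional assay (on this read-out lower numbers stand for stronger inhibition and higher numbers for weaker inhibition), and compound 2 `C=CC(C)(C)c1[nH]c2ccc(CC(=O)C(C)C)cc2c1/C=C1\NC(=O)[C@H](C)NC1=O` gives 79000 nM in this assay; the two numbers lie within the scatter of each other, as the step of a 1.1-fold lower number from compound 1 to compound 2 (0.05 log units; within the scatter) shows. Compound 3 `C=CC(C)(C)c1[nH]c2ccc(CC=C(C)C)cc2c1/C=C1\NC(=O)[C@H](C)NC1=O` continues at the same place: 2-methylprop-1-en-1-yl in place of isopropylcarbonyl on a saturated chain carbon bound to an aromatic carbon. Within the data shown here, only the step from compound 1 to compound 2 bears on it, and that step stayed within the scatter. For compound 3 no movement beyond the scatter is therefore expected, a 1.0-fold higher number from compound 2 to compound 3 (0.01 log units; within the scatter), giving an estimate of 80000 nM with a range from 30000 nM to 200000 nM in this assay.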

Compound 3, half-maximal inhibitory concentration: 98000 nM
For compound 3 the middle estimate is 1.2-fold (0.09 log units) below the measured one; the measured number falls inside the stated range.
By their numbers in this assay, from the lowest: compounds 2, 1 and 3 (each within the scatter of the next).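

Working notes: at the saturated chain carbon bound to an aromatic carbon, 2-methylprop-1-en-1-yl in place of isopropylcarbonyl removes the hydrogen-bond acceptor counted on the leaving group, and the number stays within the scatter in this assay (a 1.2-fold higher number from compound 2 to compound 3 (0.09 log units; within the scatter)). The same holds against 2,2,5,5-tetramethyl-1,3-dioxolan-4-yl (a 1.1-fold higher number from compound 1 to compound 3 (0.05 log units; within the scatter)), so all three groups at this place now lie within the scatter of one another. No supporting data bear on this result. Going by these compounds, whether an amine, a carboxylic acid or a longer chain here would move the number beyond the scatter stays open.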